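A few compounds are considered here, and "the series" means these few. Any claim that something is new, unique, unknown or untested is made for them only; others in the source may bear on it.

In a functional assay on the whole organism (Myocardium) with Canis familiaris (Canis lupus familiaris) as the target, at a dose of 8.75 mg/kg by the intravenous route (a higher number here means that more compound is needed for the effect, a lower number that less compound is needed), compound 1 `Cc1nc(O)nc2ccccc12` gives 3.45 mg/kg, compound 2 `Cc1nc(O)nc2ccc(Cl)cc12` gives 1.8 mg/kg and compound 3 `Cc1nc(O)nc2ccc(N(C)C)cc12` gives 1.2 mg/kg. Compound 2 stands in the middle of these three numbers but is not separated from either neighbour: a 1.5-fold lower number from compound 2 to compound 3 (0.18 log units; within the scatter) is the step on one side, and a 1.9-fold lower number from compound 1 to compound 2 (0.28 log units; within the scatter) is the step on the other. Compound 4 `Cc1nc(O)nc2cc(Cl)c(Cl)cc12` is derived from compound 2 by one change: chloro in place of hydrogen on an aromatic carbon. This is chloro in place of hydrogen on an aromatic carbon, ortho to a chloro group. The closest precedent is the single chloro step into compound 2 already given above, which stayed within the scatter. The step of a 2.9-fold lower number from compound 1 to compound 3 (0.46 log units; beyond the scatter) is larger, but it concerns dimethylamino and bears on this change only loosely. Within the data shown here, no compound with two chloro groups has been measured yet. A small move to a lower number is therefore expected, with nothing beyond the scatter. The expected change is a 1.4-fold lower number from compound 2 to compound 4 (0.14 log units; within the scatter). For compound 4 the estimated value is 1.3 mg/kg, with an expected range of 0.6 mg/kg to 2.8 mg/kg.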

Compound 4, dose for half-maximal effect: > 8.75 mg/kg
Compound 4: a limit, no number; the forecaster's own chance of this, stated with the estimate: 3%; at least 6.7-fold (0.82 log units) between middle value and limit.
By their numbers in this assay, from the lowest: compounds 3, 2 and 1 (each within the scatter of the next, the first and the last beyond it). At a limit, above all of these: compound 4.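

In this assay compound 4 gives > 8.75 mg/kg, which is a limit of the assay and not a number. The step of an at least 4.8-fold higher number from compound 2 to compound 4 (0.68 log units; beyond the scatter) lies beyond the scatter and runs towards more compound needed, whereas the earlier chloro in place of hydrogen, a 1.9-fold lower number from compound 1 to compound 2 (0.28 log units; within the scatter), stayed within the scatter. So the same kind of change, placed here ortho to a chloro group, does not behave like the earlier chloro step, and its full size remains unknown, as this is the only value at the limit: the limit of > 8.75 mg/kg in this assay, at which 1 of the 4 values shown sits.

The compounds shown leave open whether the shift belongs to this position alone or to the presence of two chloro groups together. They also leave open how fluoro, methoxy or a primary amine would behave on this same aromatic carbon.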